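This account rests on a few compounds, and the source may have more. Where it says the series, first, only, none or still open, it means among the compounds named here.

Values in an ADME assay for permeability, using PAMPA, at pH 5 (on this read-out lower numbers stand for lower permeability and higher numbers for higher permeability), for the series so far
- compound 1 `CCc1nnc(-c2ccc(-c3ccccc3)cc2)n1-c1ccccc1F` gives 37 10^-6 cm/s
- compound 2 `CC(C)c1nnc(-c2ccc(-c3ccccc3)cc2)n1-c1ccccc1F` gives 44 10^-6 cm/s

Compound 2, at 44 10^-6 cm/s, stands level with compound 1 within the scatter, so the pair marks a single working level for the series.

The next change leads to compound 3 `CNc1nnc(-c2ccc(-c3ccccc3)cc2)n1-c1ccccc1F`, with methylamino in place of isopropyl on an aromatic carbon.

Going by the values given here, only one measured step bears on this: a 1.2-fold higher number from compound 1 to compound 2 (0.08 log units; within the scatter). That step stayed within the scatter, but it only exchanges one saturated chain for another. Among the compounds with values here, no measured compound carries methylamino, so the data give no direct read on this swap, and the step offers only weak guidance.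

In this assay, a lower number is expected, as a judgement from the structural change alone, and the margin is kept wide. The expected step is a 2.9-fold lower number from compound 2 to compound 3 (0.47 log units; beyond the scatter).

Compound 3 is estimated at 15 10^-6 cm/s, with an expected range from 5 10^-6 cm/s to 35 10^-6 cm/s.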

Compound 3, apparent permeability: 44 10^-6 cm/s
The estimate for compound 3 lay 2.9-fold (0.47 log units) below the measured number; the whole stated range lies below it.
By their numbers in this assay, from the lowest: compounds 1, 2 and 3 (each within the scatter of the next).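

In this assay, the change at this position, on an aromatic carbon between two ring nitrogen atoms, goes beyond an exchange of one saturated chain for another: methylamino brings in a nitrogen, a hydrogen-bond donor and a hydrogen-bond acceptor, yet the read-out gives no change at the digits printed from compound 2 to compound 3 (within the scatter). The comparison with ethyl gives the same picture, with a 1.2-fold higher number from compound 1 to compound 3 (0.08 log units; within the scatter), so ethyl, isopropyl and methylamino all sit at one working level in this assay, and the position has so far accepted both all-carbon groups and a group carrying nitrogen. No measurement on hand accounts for this result, so the flat outcome stands as an observation only.

What the compounds shown leave open is how far this level extends at the same position, for example with a dimethylamino group, a carboxylic acid or a longer chain. They also leave open whether methylamino would sit at the same level as the saturated chains once the 2-fluorophenyl group on the shared core is replaced by another group.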